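The source may hold more compounds than are shown below. What is called first, only, known or untested is meant among the compounds shown, and "the series" means these compounds.

Compound 1 `COc1cccc2cc(C(=O)NC3CCCC3)c(=N)oc12` gives > 70% in an assay on CHO cells for displacement of a labelled ligand from adenosine receptor A1 (Homo sapiens), read by scintillation counting, with a stated time of 60 min, tested at 10 uM (on this read-out lower numbers stand for less inhibition and higher numbers for more inhibition at the one concentration tested (going by the name of the read-out)), which is a limit of the assay rather than a number. Compound 2 `CCC(CO)NC(=O)c1cc2cccc(OC)c2oc1=N` gives 24% in this assay. Compound 3 `CCC(CO)NC(=O)c1cc2cc(Br)ccc2oc1=N` gives 20% in this assay.

On these data alone, compound 2 and compound 1 differ by cyclopentyl in place of 1-(hydroxymethyl)propyl on an amide-type nitrogen, and the step is a number at least 46 percentage points higher from compound 2 to compound 1 (beyond the scatter); its exact size is unknown because of the limit of > 70% in this assay, at which 1 of the 3 values shown sits. Compound 4 `N=c1oc2ccc(Br)cc2cc1C(=O)NC1CCCC1` has not been measured. It differs from compound 3 by cyclopentyl in place of 1-(hydroxymethyl)propyl on an amide-type nitrogen, the same change. How the cores of compound 2 and compound 3 differ is not broken down here. The values of compound 2 and compound 3 lie within the usual scatter of each other. A step of similar size, a number 42 percentage points higher from compound 3 to compound 4 (beyond the scatter), is expected here, resting on the earlier a number at least 46 percentage points higher from compound 2 to compound 1 (beyond the scatter). For compound 4, a value of about 62% is estimated in this assay, likely between 40% and 80%.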

Compound 4, a percentage reported as inhibition, at one concentration (the size of the read-out at that concentration, not a potency): 17%
For compound 4 the middle estimate is 45 percentage points above the measured one, outside the stated range (below it).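

In this assay, putting cyclopentyl in place of 1-(hydroxymethyl)propyl on the amide-type nitrogen does not repeat its earlier effect on the core of compound 3: the step is a number 3 percentage points lower from compound 3 to compound 4 (within the scatter). The change therefore does not carry over between these two cores, and the two steps clearly disagree: the same change on two cores in this assay, a number at least 46 percentage points higher (beyond the scatter) from compound 2 to compound 1 and a number 3 percentage points lower (within the scatter) from compound 3 to compound 4, at least 49 percentage points apart, beyond the scatter of two such steps This does not show which difference between the two cores is responsible, and one pair on each core cannot show how either core would respond to other changes.

The compounds shown leave open how the same change behaves on a core carrying neither methoxy nor bromine, such as one with chlorine. They also leave open what a cyclohexyl group or a chain ending in an amine would do on the amide-type nitrogen of either core.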